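The source may hold more compounds than are shown below. What is called first, only, known or untested is meant among the compounds shown, and "the series" means these compounds.

The measured compounds:
Compound 1, `CCSc1nc(N)c2nc(O)n(Cc3ccccc3)c2n1`, gives 0.1 mg/kg in a functional assay on the whole organism for activation, with Mus musculus as the target; on this read-out lower numbers stand for an effect already at smaller amounts and higher numbers for an effect only at larger amounts of compound.
Compound 2, `Nc1ncnc2c1nc(O)n2Cc1ccc(Cl)cc1`, gives 30 mg/kg in this assay.
Compound 3, `Nc1nc(SCc2ccccc2)nc2c1nc(O)n2Cc1ccccc1`, gives in this assay only a limit, > 1 mg/kg.

Compound 3 thus stands not at a number but at the limit of > 1 mg/kg in this assay, at which 1 of the 3 values shown sits. Within the data shown here, the one step that reaches it is an at least 10-fold higher number from compound 1 to compound 3 (1.00 log units; beyond the scatter), and that step is the only guide to what the benzylsanyl-bearing side of the core tolerates. Compound 4, `CCCCCOc1nc(N)c2nc(O)n(Cc3ccccc3)c2n1`, differs from compound 3 in one place: pentyloxy in place of benzylsulfanyl on an aromatic carbon. Among the measured compounds shown here, the change takes away the phenyl ring whose arrival, from compound 1 to compound 3, went with the rise past the limit, and puts a straight chain in its place, though now on oxygen rather than sulfur, a swap for which no measured pair gives a size. Going by these compounds, the step from compound 1 to compound 3 therefore bears on compound 4 only in part: its removal of the ring argues for a lower number than the limit of compound 3, while the oxygen-for-sulfur exchange is untested. The expected step is a number no higher from compound 3 to compound 4 (the limit leaves the size open), downward but uncertain. Compound 4 is accordingly estimated at 1 mg/kg, with a range from 0.1 mg/kg to 10 mg/kg.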

Compound 4, minimum effective dose: 0.3 mg/kg
Estimate against measurement, compound 4: 3.3-fold (0.52 log units) above; the range from low to high includes it.
By their numbers in this assay, from the lowest: compound 1; then compound 4; then compound 2.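

Compound 3 carries a limit and not a number in this assay: the limit of > 1 mg/kg in this assay, at which 1 of the 4 values shown sits. Even so, pentyloxy in place of benzylsulfanyl on the aromatic carbon between two ring nitrogen atoms gives an at least 3.3-fold lower number from compound 3 to compound 4 (0.52 log units; beyond the scatter), which shows that this position can take a straight chain on oxygen and still give an effect at a smaller dose than the limit of the ring-bearing group allows. Pentyloxy in place of ethylsulfanyl on the same carbon gives a 3.0-fold higher number from compound 1 to compound 4 (0.48 log units; beyond the scatter), so the change of group does have a cost here, although compound 4 keeps its effect, and the short sulfur-linked chain of compound 1 remains the better of the two.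

The compounds shown leave open how much of that last step belongs to oxygen in place of sulfur and how much to the chain itself, a question that ethoxy or pentylsulfanyl on this carbon would separate. Also open, going by these compounds, is how an amine, or a chain longer than pentyloxy, would fare at this position, and where compound 3 truly lies beyond its limit.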